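Swapping chloro for fluoro on the thiourea-linked phenyl ring

This account rests on a few compounds, and the source may have more. Where it says the series, first, only, none or still open, it means among the compounds named here.

Measured compounds:
Compound 1, `NC(=O)c1c(NC(=O)c2ccccc2Cl)sc2c1CCN(C(=S)Nc1ccccc1F)C2`: 12600 nM
Compound 2, `NC(=O)c1c(NC(=O)c2ccccc2Br)sc2c1CCN(C(=S)Nc1ccccc1Cl)C2`: 12900 nM
Compound 3, `Cc1ccc(C(=O)Nc2sc3c(c2C(N)=O)CCN(C(=S)Nc2ccccc2Cl)C3)cc1`: 11300 nM

In a functional assay on MKN-74 cells (Homo sapiens) for antiproliferative activity, with a stated time of 24 h (on this read-out higher numbers stand for weaker inhibition and lower numbers for stronger inhibition), compound 2 gives 12900 nM, the highest of the three numbers, yet within the scatter of compound 1 and of compound 3. Going by the values given here, the one single-point step seen so far, a 1.1-fold lower number from compound 2 to compound 3 (0.06 log units; within the scatter), changed nothing beyond the scatter. Compound 4, `NC(=O)c1c(NC(=O)c2ccccc2Br)sc2c1CCN(C(=S)Nc1ccccc1F)C2`, differs from compound 2 by fluoro in place of chloro on an aromatic carbon. Among the compounds with values here, no measured step tests this change directly; compound 1, which carries the same fluoro group but a different benzoyl part, gives 12600 nM, close to compound 2. Compound 4 is therefore expected to show a 1.0-fold lower number from compound 2 to compound 4 (0.01 log units; within the scatter), that is, no step beyond the scatter. The estimate for compound 4 is 12500 nM, with a range from 6000 nM to 25000 nM.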

Compound 4, half-maximal inhibitory concentration: > 50000 nM
Compound 4 was reported as a limit; the forecaster's own chance of this, stated with the estimate: 5%; middle value at least 4.0-fold (0.60 log units) from the limit.
By their numbers in this assay, from the lowest: compounds 3, 1 and 2 (each within the scatter of the next). At a limit, above all of these: compound 4.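

Exchanging one halogen atom at this position is not a neutral change, as fluoro in place of chloro gives an at least 3.8-fold higher number from compound 2 to compound 4 (0.58 log units; beyond the scatter). Fluoro alone does not account for the result, since the group stays the same while bromo in place of chloro on the benzoyl part gives an at least 3.9-fold higher number from compound 1 to compound 4 (0.59 log units; beyond the scatter). The value of compound 4 is a limit, not a number: the limit of > 50000 nM in this assay, at which 1 of the 4 values shown sits.

From the compounds shown here alone, how far the number would move with a methoxy group or an amine in place of the halogen on this ring remains open. So does the true value of compound 4.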